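A Carbonyl Swap at the Edge of the Assay Range

The compounds below may be only part of what the source reports. "The series", "measured", "known", "first", "only" and "open" are said of these compounds alone.

Of the compounds shown here, three sharing one core have been measured in a functional assay on HT-29 cells (Homo sapiens) for inhibition, read by MTT assay, with a stated time of 48 h; on this read-out lower numbers stand for stronger inhibition and higher numbers for weaker inhibition. Compound 1 `COc1ccc(C(=O)CSc2nnc(-c3cc(OC)c(OC)c(OC)c3)n2-c2ccc(OC)cc2)cc1` gives > 60000 nM, which is a limit of the assay and not a number. Compound 2 `CCSc1nnc(-c2cc(OC)c(OC)c(OC)c2)n1-c1ccc(N(C)C)cc1` gives > 60000 nM, which is likewise only a limit. Among the compounds with values here, compound 3 `COc1ccc(C(=O)CSc2nnc(-c3cc(OC)c(OC)c(OC)c3)n2-c2ccc(N(C)C)cc2)cc1` gives 64000 nM, the only actual number among the three. The picture so far is thus set by the limit of > 60000 nM in this assay, at which 2 of the 3 values shown sit.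

Compound 4 `COc1ccc(NC(=O)CSc2nnc(-c3cc(OC)c(OC)c(OC)c3)n2-c2ccc(N(C)C)cc2)cc1` differs from compound 3 in a single place: (4-methoxyphenyl)amino in place of 4-methoxyphenyl on a carbonyl carbon. In words, (4-methoxyphenyl)amino stands in place of 4-methoxyphenyl on a carbonyl carbon.

Within the data shown here, two measured steps bear on this change, and both end at compound 3. One is a step that the limit leaves unreadable from compound 1 to compound 3, for dimethylamino in place of methoxy on an aromatic carbon. The other, closer to the site of the change, is a step that the limit leaves unreadable from compound 2 to compound 3, for (4-methoxyphenyl)carbonyl in place of methyl on a saturated chain carbon bound to a sulfur. Neither has a readable size, so neither offers a size to carry over, and the anchor remains compound 3 at 64000 nM.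

The expected change is a 1.6-fold lower number from compound 3 to compound 4 (0.20 log units; within the scatter), which would not be a step beyond the scatter. For compound 4 the estimated value is 40000 nM, with an expected range of 4000 nM to 100000 nM.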

Compound 4, half-maximal inhibitory concentration: 51400 nM
For compound 4 the middle estimate is 1.3-fold (0.11 log units) below the measured one, and the stated range covers the measured number.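

In this assay, putting (4-methoxyphenyl)amino in place of 4-methoxyphenyl on a carbonyl carbon gives a 1.2-fold lower number from compound 3 to compound 4 (0.10 log units; within the scatter), so this exchange, which brings in a hydrogen-bond donor, leaves compound 3 and compound 4 indistinguishable. The exchange of methyl on a saturated chain carbon bound to a sulfur for (4-methoxyphenyl)carbamoyl starts from a limit of the assay and reads an at least 1.1-fold lower number from compound 2 to compound 4 (0.06 log units; that floor lies within the scatter), a floor that shows no step beyond the scatter. Compound 4 thus gives a second actual number at this position, yet the series remains crowded at the same edge of the assay: the limit of > 60000 nM in this assay, at which 2 of the 4 values shown sit.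

Within the data shown here, the earlier steps ending at compound 3 still cannot be read, so what dimethylamino and the carbonyl-bearing side chain each contribute remains open even with compound 4 in hand. Also open, from the compounds shown here alone, is whether a carboxylic acid or a benzylamino group on this carbonyl carbon would give a number clearly apart from these in this assay.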